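Stereo-inverted N-methyl analogue in the integrin series

This account rests on a few compounds, and the source may have more. Where it says the series, first, only, none or still open, it means among the compounds named here.

Compound 3 (`CN1C(=O)[C@H](Cc2ccccc2)NC(=O)[C@H](CC(=O)O)NC(=O)CNC(=O)[C@H](CCCNC(=N)N)NC(=O)c2ccc(cc2)-c2cccc3c(c[nH]c23)C[C@@H]1C(N)=O`) gives the lowest number of the three measured compounds in an assay on a protein complex for binding affinity to integrin alpha-5/beta-1 (Homo sapiens), read by ELISA, with a stated time of 1 h (a higher number here means a weaker inhibitor, a lower number a stronger inhibitor), with 835 nM; compound 1 (`N=C(N)NCCC[C@@H]1NC(=O)c2ccc(cc2)-c2cccc3c(c[nH]c23)C[C@@H](C(N)=O)NC(=O)[C@@H](Cc2ccccc2)NC(=O)[C@H](CC(=O)O)NC(=O)CNC1=O`) gives 5670 nM and compound 2 (`N=C(N)NCCC[C@@H]1NC(=O)c2ccc(cc2)-c2cccc3c(c[nH]c23)C[C@H](C(N)=O)NC(=O)[C@H](Cc2ccccc2)NC(=O)[C@H](CC(=O)O)NC(=O)CNC1=O`) gives 9290 nM. Compound 4 (`CN1C(=O)[C@@H](Cc2ccccc2)NC(=O)[C@H](CC(=O)O)NC(=O)CNC(=O)[C@H](CCCNC(=N)N)NC(=O)c2ccc(cc2)-c2cccc3c(c[nH]c23)C[C@H]1C(N)=O`) differs from compound 3 as follows: the two compounds have the same atoms and bonds; at least one stereo element is drawn with a configuration in one of them and without one in the other: 2 of 5 stereo elements differ; a stereocentre at a saturated ring carbon is drawn S in compound 3 and R in compound 4; a stereocentre at a saturated ring carbon is drawn R in compound 3 and S in compound 4. Within the data shown here, the only measured step of this kind is a 1.6-fold higher number from compound 1 to compound 2 (0.21 log units; within the scatter), between the two unmethylated compounds; note (the fact that one of compounds 1 and 2 is drawn with a defined configuration and the other without, at the place where they differ). The other measured step, an 11-fold lower number from compound 2 to compound 3 (1.05 log units; beyond the scatter), concerns the methyl on the amide-type nitrogen in the ring, which compound 3 and compound 4 share, so it does not bear on the present change. On that basis no step beyond the scatter is expected in this assay from compound 3 to compound 4; if anything, a slightly lower number, as the estimated step of a 1.3-fold lower number from compound 3 to compound 4 (0.11 log units; within the scatter) reflects. Compound 4 is therefore expected to give 650 nM in this assay, within a range from 250 nM to 1800 nM.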

Compound 4, half-maximal inhibitory concentration: 2160 nM
Estimate against measurement, compound 4: 3.3-fold (0.52 log units) below, and the stated range ends below it.
By their numbers in this assay, from the lowest: compound 3; then compound 4; then compounds 1 and 2 (each within the scatter of the next).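

Inverting the two ring stereocentres stays within the scatter on the unmethylated core (a 1.6-fold higher number from compound 1 to compound 2 (0.21 log units; within the scatter)), but in this assay it goes beyond the scatter once the methyl sits on the amide-type nitrogen in the ring (a 2.6-fold higher number from compound 3 to compound 4 (0.41 log units; beyond the scatter)). The methyl also lowers the number in the other configuration (a 2.6-fold lower number from compound 1 to compound 4 (0.42 log units; beyond the scatter)), so the direction of this change holds on both cores in these four compounds. Its size does not carry over from one configuration to the other: the same change on two cores in this assay, an 11-fold lower number (1.05 log units; beyond the scatter) from compound 2 to compound 3 and a 2.6-fold lower number (0.42 log units; beyond the scatter) from compound 1 to compound 4, 4.2-fold (0.63 log units) apart, beyond the scatter of two such steps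

Going by these compounds, the reading of the configurations remains limited by how the stereocentres are drawn: the fact that one of compounds 3 and 4 is drawn with a defined configuration and the other without, at the place where they differ Whether an ethyl group or a longer chain on that nitrogen would follow the methyl in either configuration remains open.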